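The compounds below may be only part of what the source reports. "The series", "measured", "known", "first", "only" and "open" are said of these compounds alone.

Measured so far:
Compound 1, `Cc1cc(C)c(CN2CCc3c(F)cc(O[C@@H]4CCOC4)c(Cl)c3C2=O)c(=O)[nH]1` — 2.1 in a physicochemical assay for lipophilicity, at pH 7.4; a higher number here means a more lipophilic compound, a lower number a more polar compound.
Compound 2, `COc1cccc(C(=O)NCc2c(C)cc(C)[nH]c2=O)c1` — 1.7 in this assay.
Compound 3, `COc1ccc2c(c1Cl)C(=O)N(Cc1c(C)cc(C)[nH]c1=O)CCO2` — 1.3 in this assay.

Among these three numbers compound 2 stands second highest. Its nearest neighbour is compound 3, whose value is lower by a gap beyond the scatter; the furthest is compound 1, whose value is higher by a gap of the same size, also beyond the scatter. Among the compounds with values here, all three compounds share the same core, yet none of them differs from another in a single place, so no measured step can be taken as a guide.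

Compound 4, `COc1cccc(C(=O)NCc2c(C)cc(C)[nH]c2=O)c1OC`, has not yet been measured. It is compound 2 with a (methoxy in place of hydrogen on an aromatic carbon); the entering group sits on an aromatic carbon of a six-membered aromatic ring of carbon only, ortho to a large group and ortho to a methoxy group. Within the data shown here, with no measured step of this kind available, the expectation rests on the change alone: a step from compound 2 to compound 4 of no change at the digits printed from compound 2 to compound 4 (within the scatter) is expected, in neither direction beyond the scatter. Compound 4 is therefore estimated at 1.7, with a range from 1.3 to 2.1.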

Compound 4, distribution coefficient: 1.7
The estimate for compound 4 equals the measured number at the digits printed; low and high end bracket the measured number.
By their numbers in this assay, from the lowest: compound 3; then compounds 2 and 4 (each within the scatter of the next); then compound 1.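

In this assay, methoxy in place of hydrogen on an aromatic carbon, ortho to a large group and ortho to a methoxy group, gives no change at the digits printed from compound 2 to compound 4 (within the scatter). Within the data shown here, this is the first pair here that differs in one place, so it supplies a measured step that the three earlier compounds could not: at this position on this ring, the added methoxy leaves the number within the scatter, and the result holds for this single change only. Nothing available here bears on why the number stays where it does.

What the compounds shown leave open is whether a different group at this same place, such as a chlorine atom, a hydroxyl, an amine, a carboxylic acid or a longer chain such as ethoxy, would also leave the number within the scatter. Also open, as far as these compounds go, is whether methoxy entering at this place would give the same step without the neighbouring methoxy group of compound 2, or on the core of compound 1 or compound 3.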